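A few compounds are considered here, and "the series" means these few. Any claim that something is new, unique, unknown or untested is made for them only; others in the source may bear on it.

Compound 1 `COc1cc(C(=O)Nc2nn[nH]n2)nc(-c2ccc(C)cc2)c1`: 42%
Compound 2 `COc1cc(C(=O)Nc2nn[nH]n2)nc(-c2ccc(C(C)C)cc2)c1`: 54%

In a functional assay on the whole organism with Rattus norvegicus as the target, at a dose of 1 mg/kg by the oral route (a lower number here means a weaker effect, a higher number a stronger effect of the compound at the dose given), compound 1 gives 42%, the lowest of the two numbers; its nearest neighbour is compound 2, which gives 54%. Within the data shown here, the single measured step, a number 12 percentage points higher from compound 1 to compound 2 (beyond the scatter), concerns a change on the 4-methylphenyl group and is modest. Compound 3 `Cc1ccc(-c2cc(C)cc(C(=O)Nc3nn[nH]n3)n2)cc1` is not yet measured. It differs from compound 1 as follows: methyl in place of methoxy on an aromatic carbon. Among the measured compounds shown here, this change sits on the shared core, not on the 4-methylphenyl group, so the step from compound 1 to compound 2 does not bear on it directly; no measured step tells what methyl in place of methoxy does at this place. With nothing to lean on, compound 3 is expected to stay close to compound 1, and the estimated step is no change at the digits printed from compound 1 to compound 3 (within the scatter), that is, no step beyond the scatter. Compound 3 is therefore estimated at 42%, with a range from 25% to 60%.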

Compound 3, a percentage reported as inhibition, in the whole organism at one dose (the size of the read-out at that dose, not a potency): 80%
The estimate for compound 3 lay 38 percentage points below the measured number; the measured number lies above the stated range.
By their numbers in this assay, from the lowest: compound 1; then compound 2; then compound 3.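

Among these compounds, the position opposite the ring nitrogen, held as methoxy in the earlier compounds, proves sensitive in this assay: methyl in place of methoxy gives a number 38 percentage points higher from compound 1 to compound 3 (beyond the scatter). That step is large, whereas the change on the 4-methylphenyl group, a number 12 percentage points higher from compound 1 to compound 2 (beyond the scatter), is modest, so a single replacement on the shared core can shift the read-out far more than the earlier pair suggested. Nothing at hand explains the difference between methoxy and methyl at this position.

Going by these compounds, it remains open whether the higher number is particular to methyl or would also be seen with an ethyl group, a chlorine atom or an amine at this position. On these data alone, it is also open whether isopropyl in place of the methyl on the 4-methylphenyl group would raise the number further in the presence of the new methyl.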